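Trifluoromethyl for Benzyl on the Aryl Piperazine

A few compounds are considered here, and "the series" means these few. Any claim that something is new, unique, unknown or untested is made for them only; others in the source may bear on it.

Measured compounds:
compound 1 `Cc1ccccc1N1CCN(CCCNc2ncccc2C(=O)N(C)C)CC1` — 2 nM
compound 2 `CN(C)C(=O)c1cccnc1NCCCN1CCN(c2ccccc2Cc2ccccc2)CC1` — 6.31 nM

Among the compounds with values here, in a functional assay for antagonist activity at Alpha-1A adrenergic receptor (Oryctolagus cuniculus) (a lower number here means tighter binding, a higher number weaker binding), compound 2 gives 6.31 nM, the higher of the two numbers, with compound 1 the only neighbour, a step of a 3.2-fold higher number from compound 1 to compound 2 (0.50 log units; beyond the scatter). Compound 3 `CN(C)C(=O)c1cccnc1NCCCN1CCN(c2ccccc2C(F)(F)F)CC1` has not yet been measured. It differs from compound 2 by trifluoromethyl in place of benzyl on an aromatic carbon, on an aromatic carbon described as ortho to a large group. Within the data shown here, no measured step covers this exact exchange; the only step that bears on it is the one from compound 1 to compound 2, where a larger group on the same part of the structure gave a modestly higher number. Removing the benzyl in favour of a smaller trifluoromethyl is therefore expected to give a number somewhat lower, near that of compound 1, though without a direct precedent the range is wide. Compound 3 is estimated at 3 nM (range 1 nM to 10 nM), a step of a 2.1-fold lower number from compound 2 to compound 3 (0.32 log units; beyond the scatter) in this assay.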

Compound 3, dissociation constant: 12.6 nM
Estimate against measurement, compound 3: 4.2-fold (0.62 log units) below; measured number outside the range, above it.
By their numbers in this assay, from the lowest: compound 1; then compounds 2 and 3 (each within the scatter of the next).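

In this assay, exchanging benzyl for trifluoromethyl on this aromatic carbon does not separate the two compounds: the step, a 2.0-fold higher number from compound 2 to compound 3 (0.30 log units; within the scatter), leaves them indistinguishable. Removing the aromatic ring and reducing the heavy atom count therefore did not bring the number back towards that of the methyl compound, and trifluoromethyl stands apart from methyl, with a 6.3-fold higher number from compound 1 to compound 3 (0.80 log units; beyond the scatter), so that among these three groups methyl alone is distinct and the number does not follow heavy atom count. Nothing measured here explains why trifluoromethyl and benzyl read alike while methyl differs.

On these data alone, it remains open whether methoxy or chlorine on this aromatic carbon would read like methyl or like the other two groups. The compounds shown also leave open what plain hydrogen would give there.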